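Dichlorophenyl urea series: moving a chlorine on the aryl amide

The compounds below may be only part of what the source reports. "The series", "measured", "known", "first", "only" and "open" are said of these compounds alone.

Measured so far:
compound 1, `CC(C)(C)[C@H]1CC[C@H](N(Cc2ccc(C(=O)NCCC(=O)O)cc2)C(=O)Nc2ccc(Cl)c(Cl)c2)CC1`, 226 nM
compound 2, `CC(C)(C)[C@H]1CC[C@H](N(Cc2ccc(C(=O)NCCC(=O)O)cc2)C(=O)Nc2ccc(C#N)cc2OC(F)(F)F)CC1`, 215 nM
compound 3, `CC(C)(C)[C@H]1CC[C@H](N(Cc2ccc(C(=O)NCCC(=O)O)cc2)C(=O)Nc2ccc(OC(F)(F)F)cc2C#N)CC1`, 56 nM

All three share one core and differ only in the aryl group on the urea nitrogen. In an in vitro assay on BHK cells for inhibition of Glucagon receptor (Homo sapiens) (a lower number here means a stronger inhibitor, a higher number a weaker inhibitor), compound 1 gives 226 nM, the highest number of the three. Compound 2, with a nitrile and trifluoromethoxy arrangement on that aryl, gives 215 nM, which lies within the scatter of compound 1. Compound 3, in which the trifluoromethoxy and nitrile groups are swapped, gives 56 nM, a lower number than compound 1 by a margin beyond the scatter. Between compounds 2 and 3 the two values show that the arrangement of the same substituents on this aryl ring alters the readout.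

Compound 4, `CC(C)(C)[C@H]1CC[C@H](N(Cc2ccc(C(=O)NCCC(=O)O)cc2)C(=O)Nc2cc(Cl)cc(Cl)c2)CC1`, keeps the same atoms as compound 1 but joined differently: 3,5-dichlorophenyl in place of 3,4-dichlorophenyl on an amide-type nitrogen. Among the compounds with values here, no measured pair isolates this particular change. On these data alone, the comparison of compound 2 with compound 3 indicates that rearranging substituents on this ring can move the number, but the direction for a chlorine pair is untested. The step is expected to be small, with a 1.2-fold higher number from compound 1 to compound 4 (0.06 log units; within the scatter) leaning toward no change beyond the scatter. In this assay compound 4 is estimated at 260 nM, with a range from 90 nM to 750 nM.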

Compound 4, half-maximal inhibitory concentration: 80 nM
Estimate against measurement, compound 4: 3.3-fold (0.51 log units) above; the measured number lies below the stated range.
By their numbers in this assay, from the lowest: compounds 3 and 4 (each within the scatter of the next); then compounds 2 and 1 (each within the scatter of the next).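

In this assay, within the data shown here, the change from 3,4-dichlorophenyl to 3,5-dichlorophenyl on the amide-type nitrogen gives a 2.8-fold lower number from compound 1 to compound 4 (0.45 log units; beyond the scatter) and this is the first single-place step. It shows that this position responds to how the two chlorines are arranged on the aryl ring, even though the heavy atoms, the ring and the hydrogen-bond counts of the group stay the same. Among these compounds, the values of compound 2 and compound 3 had already suggested that rearranging substituents on this ring can move the number, but only this pair gives the direction for a chlorine pair, which is toward a lower number, and nothing available explains the step.

On these data alone, it remains open whether the 3,5-dichlorophenyl result depends on chlorine itself, which a phenyl ring carrying bromine or methyl in place of both chlorines would test, and how much each chlorine contributes, which an unsubstituted phenyl and the monochlorophenyl groups would help to separate. As far as these compounds go, it is also open whether the same step holds when the chain bearing the carboxylic acid is replaced by a longer chain.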